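Cytotoxicity at the Assay Limit Across Three Lactams

The source may hold more compounds than are shown below. What is called first, only, known or untested is meant among the compounds shown, and "the series" means these compounds.

Compound 1 `COc1ccc([C@H]2CC(=O)N(c3ccc(C(F)(F)F)cc3)C2)cc1OC1CCCC1` in a functional assay on HEK293 cells (Homo sapiens) for cytotoxicity (on this read-out higher numbers stand for lower toxicity in this test and lower numbers for higher toxicity in this test), gives > 10000 nM, a limit of the assay.
Compound 2 `COc1ccc([C@H]2CC(=O)N(c3ccccn3)C2)cc1OC1CCCC1` in this assay gives > 10000 nM, a limit of the assay.
Compound 3 `COc1ccc([C@H]2CC(=O)N(c3cccc(NCc4ccoc4)c3)C2)cc1OC1CCCC1` in this assay gives > 10000 nM, a limit of the assay.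

All three measured compounds sit at the same limit, as shown by the limit of > 10000 nM in this assay, at which 3 of the 3 values shown sit. For the measured compounds named here, compound 3 therefore stands where the others stand, and the only step between measured compounds, a step that the two limits leave unreadable from compound 1 to compound 2, remains unreadable because both ends are limits. Compound 4 `COc1ccc([C@H]2CC(=O)N(c3cccc(NS(=O)(=O)c4c(Br)nn(C)c4Cl)c3)C2)cc1OC1CCCC1` differs from compound 3 by (3-bromo-5-chloro-1-methyl-1H-pyrazol-4-yl)sulfonyl in place of (furan-3-yl)methyl on a nitrogen on an aromatic ring. Going by the values given here, no measured step bears directly on this change, and the one step available gives no size at all. With every value at the limit and no readable step, compound 4 is expected to remain at that limit, so the estimated step that the limit leaves unreadable from compound 3 to compound 4 is none beyond the scatter. Compound 4 is therefore estimated at 15000 nM, in the range from 7000 nM to 40000 nM, with a limit rather than a number being the most likely outcome.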

Compound 4, half-maximal cytotoxic concentration: > 10000 nM
Compound 4: only a limit was reported; the forecaster's own chance of this, stated with the estimate: 85%; the middle value is on the limit's open side.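

In this assay compound 4 gives > 10000 nM, which is a limit of the assay. Compound 3 also stands at a limit, so no step can be read between compound 3 and compound 4: the limit of > 10000 nM in this assay, at which 4 of the 4 values shown sit.

The compounds shown leave open what actual half-maximal cytotoxic concentration any of them has.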